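Swapping a Pyridine for a Fluorophenyl

The source may hold more compounds than are shown below. What is called first, only, known or untested is meant among the compounds shown, and "the series" means these compounds.

Measured so far in a functional assay on MDA-MB-231 cells (Homo sapiens) for antiproliferative activity, read by MTT assay, with a stated time of 72 h; a lower number here means a stronger inhibitor, a higher number a weaker inhibitor
- compound 1 `CC1=CC[C@H]2[C@H](CC[C@]2(C)O)C(C)(C)[C@@H]1CC[C@H]1[C@]2(C)CC[C@H](OC(=O)c3ccncc3)C(C)(C)O[C@H]2CC[C@@]1(C)O` gives 18000 nM
- compound 2 `CC1=CC[C@H]2[C@H](CC[C@]2(C)O)C(C)(C)[C@@H]1CC[C@H]1[C@]2(C)CC/C(=N/O)C(C)(C)O[C@H]2CC[C@@]1(C)O` gives 42700 nM

Compound 1 has the lower of these two numbers, which makes it the stronger inhibitor of the pair, and the gap to compound 2 lies beyond the scatter. The next compound to be tested is compound 3 `CC1=CC[C@H]2[C@H](CC[C@]2(C)O)C(C)(C)[C@@H]1CC[C@H]1[C@]2(C)CC[C@H](OC(=O)c3ccc(F)cc3)C(C)(C)O[C@H]2CC[C@@]1(C)O`. It keeps the core of compound 1 and has 4-fluorophenyl in place of pyridin-4-yl on a carbonyl carbon. Within the data shown here, no pair of measured compounds differs in one place, so the data offer no direct guide to this swap. The expectation in this assay is therefore no step beyond the scatter, in either direction. The estimate amounts to an expected 1.1-fold lower number from compound 1 to compound 3 (0.05 log units; within the scatter) and stays close to the number of compound 1 (18000 nM). Compound 3 is expected at 16000 nM (estimated range 6500 nM to 40000 nM).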

Compound 3, half-maximal inhibitory concentration: 11300 nM
Compound 3: the middle estimate sits 1.4-fold (0.15 log units) above what was measured, and the stated range covers the measured number.
By their numbers in this assay, from the lowest: compounds 3 and 1 (each within the scatter of the next); then compound 2.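

In this assay, putting 4-fluorophenyl in place of pyridin-4-yl on the carbonyl carbon gives a 1.6-fold lower number from compound 1 to compound 3 (0.20 log units; within the scatter) and so no real change. For this pair, the ring nitrogen of pyridin-4-yl is therefore not needed to keep the activity, and an aromatic ring of carbon only carrying a fluorine serves equally well at this position. No measured evidence accounts for this result.

The swap removes the ring nitrogen and adds a fluorine at once, so the two compounds cannot show what each change does alone; an unsubstituted phenyl group would separate them. Also open, going by these compounds, is whether this position needs an aromatic ring at all, which a cyclohexyl group or a longer alkyl chain on the same carbonyl carbon would test.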